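Carbamoyl in Place of Hydrogen, Measured Once, Expected Again

The compounds below may be only part of what the source reports. "The series", "measured", "known", "first", "only" and "open" are said of these compounds alone.

Measured so far:
Compound 1, `COc1cc2c(cc1NS(=O)(=O)c1cccc(Cl)c1Cl)[nH]c(=O)n2C`, gives 3.8 in a physicochemical assay for lipophilicity, at pH 7.4; a lower number here means a more polar compound, a higher number a more lipophilic compound.
Compound 2, `COc1cc2c(cc1NS(=O)(=O)c1cccc(Cl)c1Cl)[nH]c(=O)n2CC(N)=O`, gives 2.5 in this assay.
Compound 3, `COc1cc2[nH]c(=O)n(C)c2cc1NS(=O)(=O)c1cccc(Cl)c1Cl`, gives 3.7 in this assay.

Compound 1 and compound 2 share a core and differ in one place only: carbamoyl in place of hydrogen on a saturated chain carbon bound to an aromatic nitrogen

That single change moved the read-out by a number 1.30 log units lower from compound 1 to compound 2 (beyond the scatter), a clear drop in lipophilicity rather than measurement noise.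

Compound 3 is built from the same atoms as compound 1, joined differently; how the two cores differ is not broken down here. In this assay compound 3 and compound 1 sit so close together that no difference between them can be claimed, while compound 2 stands clearly apart from both.

Compound 4, `COc1cc2[nH]c(=O)n(CC(N)=O)c2cc1NS(=O)(=O)c1cccc(Cl)c1Cl`, has not yet been measured. It relates to compound 3 exactly as compound 2 relates to compound 1: carbamoyl in place of hydrogen on a saturated chain carbon bound to an aromatic nitrogen

Because the same change on the core of compound 1 produced the step of a number 1.30 log units lower from compound 1 to compound 2 (beyond the scatter), a step of similar size is expected here, namely a number 1.30 log units lower from compound 3 to compound 4 (beyond the scatter). This expectation rests on a single earlier pair, so it carries the uncertainty of one example. On that basis compound 4 is estimated to give 2.4 in this assay, with the value expected to lie between 1.9 and 2.9.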

Compound 4, distribution coefficient: 2.4
For compound 4 middle estimate and measured number coincide at the digits printed; measured number inside the range.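

Read in this assay the change from methyl to carbamoylmethyl now stands on two cores: it gave a number 1.30 log units lower from compound 1 to compound 2 (beyond the scatter) and also a number 1.30 log units lower from compound 3 to compound 4 (beyond the scatter) and these two steps have the same size at the digits printed. For these compounds, then, the change carried over from the core of compound 1 to the core of compound 3 with no visible loss in the size of the step, and neither pair goes against the other. Still, two pairs on two cores built from the same atoms show only that the step repeated here, not that it would repeat on any other core in the series, and nothing shown offers a measured reason for the size of the step.

Hydrogen and carbamoyl are the only groups compared at this place, so it stays open whether a carboxylic acid, an amine or a longer chain ending in carbamoyl would give a step of similar size, and whether such a step would again match between the two cores. Equally open, as far as these compounds go, is how compound 3 and compound 4 compare in any read-out other than this assay such as a biological test of activity.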